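Swapping Phenyl for Furan-2-yl on a Shared Core

This account rests on a few compounds, and the source may have more. Where it says the series, first, only, none or still open, it means among the compounds named here.

Measured compounds in a functional assay on MCF7 cells (Homo sapiens) for cytotoxicity, read by sulforhodamine B assay, with a stated time of 72 h; on this read-out lower numbers stand for stronger inhibition and higher numbers for weaker inhibition:
compound 1 `Cc1c(-c2csc(/N=c3\sc(-c4ccccc4)nn3-c3ccccc3)n2)c(=O)n(-c2ccccc2)n1C` gives > 100000 nM, a limit of the assay.
compound 2 `CCOC(=O)c1nn(-c2ccccc2)/c(=N/c2nc(-c3c(C)n(C)n(-c4ccccc4)c3=O)cs2)s1` gives > 100000 nM, a limit of the assay.
compound 3 `Cc1c(-c2csc(/N=C3\S/C(=C\c4ccccc4)C(=O)N3c3ccccc3)n2)c(=O)n(-c2ccccc2)n1C` gives > 100000 nM, a limit of the assay.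

Compound 3 therefore stands at the limit, and the limit of > 100000 nM in this assay, at which 3 of the 3 values shown sit, records that every value shown sits there. Within the data shown here, the only one-place step, a step that the two limits leave unreadable from compound 1 to compound 2, runs between two limits, so its size cannot be read. Compound 4 `Cc1c(-c2csc(/N=C3\S/C(=C\c4ccco4)C(=O)N3c3ccccc3)n2)c(=O)n(-c2ccccc2)n1C` differs from compound 3 by furan-2-yl in place of phenyl on a double-bonded chain carbon bound to a double-bonded ring carbon. No measured step bears on this change, and nothing shown tells whether a number beneath the limit can be reached. The step from compound 3 to compound 4 is expected to be a number no higher from compound 3 to compound 4 (the limit leaves the size open), with a limit again the most likely report. Compound 4 is estimated at 100000 nM, expected to lie between 30000 nM and 300000 nM.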

Compound 4, half-maximal inhibitory concentration: 22400 nM
Estimate against measurement, compound 4: 4.5-fold (0.65 log units) above; the measured number lies below the stated range.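

In this assay, the double-bonded chain carbon bound to a double-bonded ring carbon proves sensitive to change: furan-2-yl in place of phenyl gives an at least 4.4-fold lower number from compound 3 to compound 4 (0.64 log units; beyond the scatter). Compound 4 is the first compound shown with a number beneath the limit, so a measurable value can be reached on this shared core. The step's full size remains unknown because compound 3 has only a limit: the limit of > 100000 nM in this assay, at which 3 of the 4 values shown sit.

The compounds shown do not separate the effect of the furan oxygen from that of the five-membered ring. They also leave open how thiophen-2-yl or pyridin-2-yl would fare at this place.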